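A few compounds are considered here, and "the series" means these few. Any claim that something is new, unique, unknown or untested is made for them only; others in the source may bear on it.

Compound 1 `COc1ccc(CN(C(=O)C2CC2)c2cc(OC)c(OC)c(OC)c2)cc1O` is an amide in which a cyclopropyl ring sits on the carbonyl carbon. In a functional assay on MGC-803 cells (Homo sapiens) for inhibition, read by MTT assay, with a stated time of 48 h (on this read-out higher numbers stand for weaker inhibition and lower numbers for stronger inhibition), compound 1 gives 59 nM, the lower of the two numbers measured here. Compound 2 `C/C=C/C(=O)N(Cc1ccc(OC)c(Br)c1)c1cc(OC)c(OC)c(OC)c1` gives 6430 nM in this assay, and its gap to compound 1 is beyond the usual scatter. Compound 3 `COc1ccc(CN(C(=O)CN=[N+]=[N-])c2cc(OC)c(OC)c(OC)c2)cc1O` is not yet measured; it differs from compound 1 in one place: azidomethyl in place of cyclopropyl on a carbonyl carbon. Within the data shown here, no measured pair shows this change, so compound 3 is expected to take a modest step toward weaker inhibition, a 2.5-fold higher number from compound 1 to compound 3 (0.41 log units; beyond the scatter), possibly within the scatter. Compound 3 is estimated at 150 nM, within 40 nM to 600 nM.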

Compound 3, half-maximal inhibitory concentration: 120 nM
Compound 3: middle estimate off by 1.3-fold (0.10 log units), on the high side; the measured number falls inside the stated range.
By their numbers in this assay, from the lowest: compound 1; then compound 3; then compound 2.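

In this assay, putting azidomethyl in place of cyclopropyl on the carbonyl carbon gives a 2.0-fold higher number from compound 1 to compound 3 (0.31 log units; beyond the scatter), a modest step. This position therefore accepts a group without a ring at only a small cost, so the three-membered ring is not essential for activity in this series. No available measurement explains why the number rises. Still open, on these data alone, is how an aminomethyl group, a carboxylic acid or a longer carbon chain would fare on this carbonyl carbon, and whether a larger ring such as cyclobutyl would match cyclopropyl.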